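The source may report more compounds than this note shows. Statements on the series, on what has been measured and on what is new or still open speak of the compounds shown alone.

Compound 1 `COc1cccc(CNCCCNc2ccnc3cc(C4CCCCC4)ccc23)c1O` and compound 2 `c1coc(CNCCCNc2ccnc3cc(C4CCCCC4)ccc23)c1` share one core and differ only in the group on a saturated chain carbon bound to an amine nitrogen. In an ADME assay for permeability, using PAMPA, with a stated time of 30 min, at pH 7.4 (a higher number here means that the compound crosses the layer faster, a lower number that the compound crosses the layer more slowly), compound 1 gives 23 10^-6 cm/s and compound 2 gives 23 10^-6 cm/s; the step of no change at the digits printed from compound 1 to compound 2 (within the scatter), so compound 1 stands level with compound 2. Compound 3 `COc1cccc(CNCCCNc2ccnc3cc(-c4cccc5ccccc45)ccc23)c1O` differs from compound 1 elsewhere: naphthalen-1-yl in place of cyclohexyl on an aromatic carbon. Going by the values given here, no measured step touches this position, so the single measured step gives no direct guide. With both measured values alike, the step of a 1.2-fold lower number from compound 1 to compound 3 (0.06 log units; within the scatter) for compound 3 is expected to stay within the scatter. Compound 3 is estimated at 20 10^-6 cm/s, between 10 10^-6 cm/s and 40 10^-6 cm/s.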

Compound 3, apparent permeability: 237 10^-6 cm/s
Compound 3: middle estimate off by 12-fold (1.07 log units), on the low side; the whole stated range lies below it.
By their numbers in this assay, from the lowest: compounds 1 and 2 (each within the scatter of the next); then compound 3.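

Going by these compounds alone, the group on this aromatic carbon matters in this assay, whereas the one step at the chain end, no change at the digits printed from compound 1 to compound 2 (within the scatter), gave no separation. Naphthalen-1-yl in place of cyclohexyl gives a 10-fold higher number from compound 1 to compound 3 (1.01 log units; beyond the scatter), so this position can move the read-out strongly even when the rest of compound 1 stays the same. Nothing measured here explains the rise.

From the compounds shown here alone, whether the rise follows from the aromatic rings or from the added carbons stays open, and a phenyl group on this aromatic carbon would help separate the two. Whether it would also hold with furan-2-yl at the chain end is equally unknown.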